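A few compounds are considered here, and "the series" means these few. Any claim that something is new, unique, unknown or untested is made for them only; others in the source may bear on it.

Compound 1 `CCCCCNc1nccnc1C(=O)NCc1ccccc1` and compound 2 `CCCCCCCCNc1cncc(C(=O)NCc2ccccc2)n1` were both examined in an ADME assay on HeLa cells (Homo sapiens) for cytotoxicity, read by microscopy, with a stated time of 6 days; a higher number here means that more compound is tolerated, a lower number that less compound is tolerated. Compound 1 reaches the limit of the assay, reported as > 100000 nM. Compound 2 likewise gives no number but the limit, reported as > 100000 nM. Among the compounds with values here, both values therefore sit at the limit of > 100000 nM in this assay, at which 2 of the 2 values shown sit, and compound 2 stands exactly where every value so far stands. Compound 3 `CCCCCNc1cncc(C(=O)NCc2ccccc2)n1` differs from compound 2 by hydrogen in place of propyl on a saturated chain carbon, five bonds along the chain from a nitrogen on an aromatic ring. Within the data shown here, no measured step between related compounds is available, so compound 3 is expected to stay at the limit, with a step of a number no higher from compound 2 to compound 3 (the limit leaves the size open) of no size beyond the scatter. Compound 3 is estimated at 100000 nM, within 50000 nM to 300000 nM.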

Compound 3, minimum cytotoxic concentration: > 100000 nM
Compound 3 gave a limit, no number; the forecaster's own chance of this, stated with the estimate: 85%; the middle value lies on the limit itself.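

No step from compound 2 to compound 3 can be read, and both compounds give only a limit: the limit of > 100000 nM in this assay, at which 3 of the 3 values shown sit.

The compounds shown leave open whether hydrogen in place of propyl changes cytotoxicity at all, since none gives a measured number.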